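Three limits, then a naphthyloxy variant of the hydrazide

The source may hold more compounds than are shown below. What is called first, only, known or untested is meant among the compounds shown, and "the series" means these compounds.

The shared core carries an acylhydrazone arm, and three of its acyl groups have been tested in an assay for inhibition of Polyunsaturated fatty acid lipoxygenase ALOX15 (Homo sapiens), with a stated time of 8 min; on this read-out higher numbers stand for weaker inhibition and lower numbers for stronger inhibition. Compound 1 `CCOC(=O)c1[nH]c2cc(Cl)ccc2c1/C=N/NC(=O)CCC(C)C` gives only a limit of the assay in this assay, > 10000 nM. Compound 2 `CCOC(=O)c1[nH]c2cc(Cl)ccc2c1/C=N/NC(=O)CC1CCCC1` likewise gives only a limit, > 10000 nM. Compound 3 `CCOC(=O)c1[nH]c2cc(Cl)ccc2c1/C=N/NC(=O)COc1ccc([N+](=O)[O-])cc1` too stands at a limit, > 10000 nM. Between these three compounds the steps are a step that the two limits leave unreadable from compound 1 to compound 2, a step that the two limits leave unreadable from compound 1 to compound 3 and a step that the two limits leave unreadable from compound 2 to compound 3, so no direction can be drawn, and the only evidence is the limit of > 10000 nM in this assay, at which 3 of the 3 values shown sit.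

Compound 4 `CCOC(=O)c1[nH]c2cc(Cl)ccc2c1/C=N/NC(=O)COc1cccc2ccccc12` differs from compound 3 by naphthalen-1-yl in place of 4-nitrophenyl on an oxygen on a saturated carbon. Within the data shown here, none of the measured steps can be read, so they give no size and no direction for this change; the common feature of the measured set is that every acyl variant has failed to reach a numerical value in this assay. On that basis the step from compound 3 to compound 4 is expected to be a step that the limit leaves unreadable from compound 3 to compound 4, meaning no readable movement. Compound 4 is therefore estimated at 15000 nM in this assay, with a range from 3000 nM to 60000 nM, and most probably reported again as a limit.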

Compound 4, half-maximal inhibitory concentration: > 10000 nM
Compound 4 gave a limit, no number (the forecaster's own chance of this, stated with the estimate: 75%); the middle value is on the limit's open side.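

In this assay compound 4 gives > 10000 nM, a limit and not a number, and compound 3 also stands at a limit, so the step between them cannot be read. The compounds shown leave open whether any acyl group on the shared core reaches a numerical value in this assay, and how these acyl groups compare: the limit of > 10000 nM in this assay, at which 4 of the 4 values shown sit.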